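Isopropoxy in place of ethoxy on the benzodioxinylmethyl analogue

A few compounds are considered here, and "the series" means these few. Any claim that something is new, unique, unknown or untested is made for them only; others in the source may bear on it.

Compound 3 `CCOc1ccccc1N1CCN(CCCCCCCn2ncc(N3CCN(CC4COc5ccccc5O4)CC3)c(Cl)c2=O)CC1` holds the second highest of the three numbers in an assay on cell membranes for binding affinity to Adrenergic receptor alpha-1 (Rattus norvegicus), read by radioligand binding; on this read-out lower numbers stand for stronger inhibition and higher numbers for weaker inhibition: compound 3 gives 0.42 nM, close to compound 1 `CCOc1ccccc1N1CCN(CCCCCCCn2ncc(N3CCN(C(=O)c4ccco4)CC3)c(Cl)c2=O)CC1`, which gives 0.5 nM, and far from compound 2 `CC(C)Oc1ccccc1N1CCN(CCCCCCCn2ncc(N3CCN(C(=O)c4ccco4)CC3)c(Cl)c2=O)CC1`, which gives 0.052 nM. Compound 4 `CC(C)Oc1ccccc1N1CCN(CCCCCCCn2ncc(N3CCN(CC4COc5ccccc5O4)CC3)c(Cl)c2=O)CC1` differs from compound 3 by methyl in place of hydrogen on a saturated chain carbon bound to an oxygen on an aromatic ring and a saturated chain carbon. The same change, made on the furanoylpiperazine pair, gave a 9.6-fold lower number from compound 1 to compound 2 (0.98 log units; beyond the scatter), while the exchange of the piperazine substituent alone gave a 1.2-fold lower number from compound 1 to compound 3 (0.08 log units; within the scatter). One precedent is a thin base, yet it points one way, so a step of about the same size and direction is expected in this assay, an 8.4-fold lower number from compound 3 to compound 4 (0.92 log units; beyond the scatter). Compound 4 is therefore estimated at 0.05 nM, with a range from 0.015 nM to 0.2 nM.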

Compound 4, inhibition constant: 0.31 nM
Compound 4: the middle estimate sits 6.2-fold (0.79 log units) below what was measured; measured number outside the range, above it.
By their numbers in this assay, from the lowest: compound 2; then compounds 4, 3 and 1 (each within the scatter of the next).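

With (2,3-dihydro-1,4-benzodioxin-2-yl)methyl on the amine nitrogen, ethoxy to isopropoxy gives only a 1.4-fold lower number from compound 3 to compound 4 (0.13 log units; within the scatter) in this assay. For the compounds shown here, the change therefore has no fixed effect at this position, and its large step is seen only with (furan-2-yl)carbonyl: the same change on two cores in this assay, a 9.6-fold lower number (0.98 log units; beyond the scatter) from compound 1 to compound 2 and a 1.4-fold lower number (0.13 log units; within the scatter) from compound 3 to compound 4, 7.1-fold (0.85 log units) apart, beyond the scatter of two such steps. Read the other way, exchanging that group on the isopropoxy pair gives a 6.0-fold higher number from compound 2 to compound 4 (0.78 log units; beyond the scatter), so the two changes do not simply add: the same change on two cores in this assay, a 1.2-fold lower number (0.08 log units; within the scatter) from compound 1 to compound 3 and a 6.0-fold higher number (0.78 log units; beyond the scatter) from compound 2 to compound 4, 7.1-fold (0.85 log units) apart, beyond the scatter of two such steps.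

The compounds shown leave open whether tert-butoxy or cyclopropoxy would keep the low number of compound 2 on its core. They also leave open whether this dependence survives a shorter chain.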